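Cytotoxicity notes on a triazole-linked diterpenoid series

The source may report more compounds than this note shows. Statements on the series, on what has been measured and on what is new or still open speak of the compounds shown alone.

Compound 1 `Cc1c(O)ccc2c1[C@H](Cn1cc(-c3ccc(C(F)(F)F)cc3)nn1)[C@@]13CC(=O)[C@@](C)(CC[C@@H]21)C3`: in a functional assay on A549 cells (Homo sapiens) for cytotoxicity, read by MTT assay, with a stated time of 4 days (a higher number here means a weaker inhibitor, a lower number a stronger inhibitor), compound 1 gives > 20000 nM, which is a limit of the assay and not a number.
Compound 2 `Cc1ccc(-c2cn(C[C@H]3c4c(ccc(O)c4C)[C@@H]4CC[C@@]5(C)C[C@]43CC5=O)nn2)cc1`: in this assay compound 2 gives > 20000 nM, again only a limit.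
Compound 3 `C=C1C[C@]23C[C@@]1(O)CC[C@@H]2c1cccc(C)c1[C@@H]3Cn1cc(-c2ccc(C(F)(F)F)cc2)nn1`: in this assay compound 3 gives > 20000 nM, again only a limit.

Compound 2 arises from compound 1 by methyl in place of trifluoromethyl on an aromatic carbon. The resulting step, a step that the two limits leave unreadable from compound 1 to compound 2, cannot be sized, since both ends sit at the limit of > 20000 nM in this assay, at which 3 of the 3 values shown sit.

Compound 3 and compound 1 share the triazole-linked aryl group but the difference between the two cores is not broken down here. Compound 4 `C=C1C[C@]23C[C@@]1(O)CC[C@@H]2c1cccc(C)c1[C@@H]3Cn1cc(-c2ccc(C)cc2)nn1`, still to be measured, arises from compound 3 by methyl in place of trifluoromethyl on an aromatic carbon, the same change as from compound 1 to compound 2, at a place described in identical words.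

For compound 4 the step that the limit leaves unreadable from compound 3 to compound 4 is expected to remain unreadable, resting on compound 1 and compound 2 both sitting at the limit of > 20000 nM in this assay, at which 3 of the 3 values shown sit. Compound 4 is therefore estimated at 30000 nM in this assay, between 12000 nM and 100000 nM, most likely reported as a limit only.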

Compound 4, half-maximal inhibitory concentration: > 20000 nM
Compound 4: only a limit was reported; the forecaster's own chance of this, stated with the estimate: 85%; the middle value is on the limit's open side.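

No step can be read from compound 3 to compound 4, since both ends sit at one limit and give no number: the limit of > 20000 nM in this assay, at which 4 of the 4 values shown sit.

The compounds shown leave open whether 4-methylphenyl and 4-(trifluoromethyl)phenyl differ at all in this assay, on either core, as no readable value exists for any of them.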